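From phenyl to 2,3-dimethylphenyl on compound 2

The compounds below may be only part of what the source reports. "The series", "measured", "known", "first", "only" and "open" are said of these compounds alone.

- compound 1 `CCCC[C@H]1CN(c2cccc(C)c2C)C(=O)CN1Cc1cncn1Cc1ccc(C#N)cc1`: > 3.7 (a limit)
- compound 2 `N#Cc1ccc(Cn2cncc2CN2CCN(c3ccccc3)C(=O)C2)cc1`: 1.32
- compound 3 `N#Cc1ccc(Cn2cncc2CN2CCN(c3ccccc3)C(=O)C2=O)cc1`: 0.46

In a physicochemical assay for lipophilicity (a lower number here means a more polar compound, a higher number a more lipophilic compound), compound 2 gives 1.32, the higher of the two true numbers, and compound 3 gives 0.46, lower by more than the scatter. Compound 4 `Cc1cccc(N2CCN(Cc3cncn3Cc3ccc(C#N)cc3)CC2=O)c1C` carries 2,3-dimethylphenyl in place of phenyl on an amide-type nitrogen in a ring. Compound 1 also bears 2,3-dimethylphenyl and reads > 3.7, which is a limit and not a number. Within the data shown here, no measured pair shows this change alone, so its size in this assay is a judgement. A moderate rise beyond the scatter is expected, estimated as a number 0.88 log units higher from compound 2 to compound 4 (beyond the scatter). Compound 4 is estimated at 2.2, with an expected range of 1.8 to 2.7.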

Compound 4, partition coefficient: 2
Beside the measured number, compound 4's estimate is 0.20 log units above it, and the stated range covers the measured number.
By their numbers in this assay, from the lowest: compound 3; then compound 2; then compound 4. At a limit, above all of these: compound 1.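

In this assay, 2,3-dimethylphenyl in place of phenyl on an amide-type nitrogen in a ring now has a measured size of its own, giving a number 0.68 log units higher from compound 2 to compound 4 (beyond the scatter). Hydrogen in place of butyl on a saturated ring carbon gives a number at least 1.70 log units lower from compound 1 to compound 4 (beyond the scatter). That second step rests on a limit for compound 1 and not on a true number: the limit of > 3.7 in this assay, at which 1 of the 4 values shown sits.

Going by these compounds, how a single methyl or a methoxy on that phenyl would read remains open. So does the reading of a shorter chain, such as ethyl, in place of butyl.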